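The compounds below may be only part of what the source reports. "The series", "measured", "known", "first", "only" and "open" are said of these compounds alone.

In an assay on a cell-free system (plasma) for inhibition of Dipeptidyl peptidase 4 (Rattus norvegicus), read by fluorescence (on this read-out lower numbers stand for stronger inhibition and higher numbers for weaker inhibition), compound 1 `N#Cc1cccnc1N1CCN([C@@H]2CN[C@H](C(=O)N3CCSC3)C2)CC1` gives 1.2 nM, and compound 2 `O=C([C@@H]1C[C@H](N2CCN(c3ccc(Cl)cn3)CC2)CN1)N1CCSC1` gives 3.1 nM. Within the data shown here, the single step between them, a 2.6-fold higher number from compound 1 to compound 2 (0.41 log units; beyond the scatter), puts compound 2 at the higher of the two numbers in this assay, set apart from compound 1 by more than the scatter. Compound 3 `O=C([C@@H]1C[C@H](N2CCN(c3cccc(Cl)c3)CC2)CN1)N1CCSC1` differs from compound 2 by 3-chlorophenyl in place of 5-chloropyridin-2-yl on an amine nitrogen in a ring. Among the measured compounds shown here, the only measured step that bears on this change is the one from compound 1 to compound 2, which also swapped the aromatic group on that same ring nitrogen and was modest in size. For the measured compounds named here, the two changes are not the same: the data hold no example of a carbon-only ring replacing a pyridine at that position. Compound 3 is therefore expected to move only modestly in this assay, a 1.9-fold higher number from compound 2 to compound 3 (0.29 log units; within the scatter), toward a somewhat higher number. The estimate for compound 3 is 6 nM, with a range from 2 nM to 20 nM.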

Compound 3, half-maximal inhibitory concentration: 7.2 nM
Compound 3: the middle estimate sits 1.2-fold (0.08 log units) below what was measured, and the stated range covers the measured number.
By their numbers in this assay, from the lowest: compound 1; then compound 2; then compound 3.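

In this assay, among these compounds, the step to a carbon-only ring at this amine nitrogen is a 2.3-fold higher number from compound 2 to compound 3 (0.37 log units; beyond the scatter), so it is the first sign that losing the pyridine ring nitrogen, with the chlorine also placed differently, can raise the number beyond the scatter. Set against the nitrile-bearing pyridine, the same group gives a 6.0-fold higher number from compound 1 to compound 3 (0.78 log units; beyond the scatter), the widest gap among these compounds, yet it is still printed as modest, and all three aromatic groups stay in the low nanomolar range. No measurement given here accounts for either step.

These compounds leave open how much of the change belongs to the ring nitrogen and how much to where the chlorine stands. An unsubstituted phenyl or a cyanophenyl group on the same nitrogen would help separate the two.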